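Thiophen-2-yl in place of thiophen-3-yl: expected inhibition

The source may report more compounds than this note shows. Statements on the series, on what has been measured and on what is new or still open speak of the compounds shown alone.

In a functional assay on DU-145 cells (Homo sapiens) for inhibition, read by sulforhodamine B assay, with a stated time of 48 h, tested at 10 uM (on this read-out lower numbers stand for less inhibition and higher numbers for more inhibition at the one concentration tested (going by the name of the read-out)), compound 1 `Brc1cn2ccnc2c(-c2ccc3ncn(C4CCCCC4)c3c2)n1` gives 6.2%, compound 2 `Fc1ccc(-c2cn3ccnc3c(-c3ccc4ncn(C5CCCCC5)c4c3)n2)cc1` gives 1.17%, and compound 3 `c1cn2cc(-c3ccsc3)nc(-c3ccc4ncn(C5CCCCC5)c4c3)c2n1` gives 1.36%. Compound 3 stands second highest of the three numbers; the step of a number 0.2 percentage points higher from compound 2 to compound 3 (within the scatter) lies within the scatter, as does a number 4.8 percentage points lower from compound 1 to compound 3 (within the scatter). Compound 4 `c1csc(-c2cn3ccnc3c(-c3ccc4ncn(C5CCCCC5)c4c3)n2)c1` differs from compound 3 in one place: thiophen-2-yl in place of thiophen-3-yl on an aromatic carbon. For the measured compounds named here, no measured step exchanges one thiophene attachment for the other; the steps that vary this same position, a number 5 percentage points lower from compound 1 to compound 2 (within the scatter) and a number 4.8 percentage points lower from compound 1 to compound 3 (within the scatter), both stay within the scatter, so the varied group here has not moved the read-out beyond the scatter. For compound 4 the step of a number 0.6 percentage points higher from compound 3 to compound 4 (within the scatter) is therefore expected to be none beyond the scatter. Compound 4 is estimated at 2%, in the range 0% to 8%.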

Compound 4, a percentage reported as inhibition, at one concentration (the size of the read-out at that concentration, not a potency): 5.07%
Estimate against measurement, compound 4: 3.1 percentage points below; measured number inside the range.
By their numbers in this assay, from the lowest: compounds 2, 3, 4 and 1 (each within the scatter of the next).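

The direct exchange of one thiophene attachment for the other at this position stays within the scatter in this assay (a number 3.7 percentage points higher from compound 3 to compound 4 (within the scatter)). Thiophen-2-yl is also within the scatter of the other two groups (a number 3.9 percentage points higher from compound 2 to compound 4 (within the scatter); a number 1.1 percentage points lower from compound 1 to compound 4 (within the scatter)), so none of the four groups shown at this position is separated from another. No measurement available here offers an explanation for these numbers.

On these data alone, whether an amine or a carboxylic acid on this aromatic carbon would move the read-out beyond the scatter remains open. So does whether any change elsewhere on the shared core would do so.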